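This account rests on a few compounds, and the source may have more. Where it says the series, first, only, none or still open, it means among the compounds named here.

Measured compounds in an assay on IMR-32 cells for displacement of a labelled ligand from corticotropin-releasing factor receptor 1 (Homo sapiens), read by scintillation counting, with a stated time of 2 h; a lower number here means a stronger inhibitor, a higher number a weaker inhibitor:
- compound 1, `CCc1nc(-c2ccc(Cl)cc2Cl)c(CC)nc1NC(CC)CC`: 4.1 nM
- compound 2, `CCCN(CC1CC1)c1nc(CC)c(-c2ccc(Cl)cc2Cl)nc1CC`: 19.2 nM
- compound 3, `CCc1nc(-c2ccc(Cl)cc2Cl)c(CC)nc1CC(CC)CC`: 68 nM

Compound 3 gives the highest number of the three in this assay. Its nearest neighbour is compound 2, with a 3.5-fold higher number from compound 2 to compound 3 (0.55 log units; beyond the scatter) separating them; compound 1 lies furthest off, with a 17-fold higher number from compound 1 to compound 3 (1.22 log units; beyond the scatter). Both steps sit beyond the scatter, so compound 3 is the weakest binder of the measured set.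

Compound 4, `CCc1nc(N(CC2CC2)CC2CC2)c(CC)nc1-c1ccc(Cl)cc1Cl`, has not yet been measured. It differs from compound 3 in one place: bis(cyclopropylmethyl)amino in place of 2-ethylbutyl on an aromatic carbon.

The step that bears most directly on this change is a 3.5-fold higher number from compound 2 to compound 3 (0.55 log units; beyond the scatter), in which a 2-ethylbutyl group took the place of a (cyclopropylmethyl)(propyl)amino group and the number rose modestly. Compound 4 carries a bis(cyclopropylmethyl)amino group, which shares the amino attachment and one cyclopropylmethyl arm with the group of compound 2. The reversal of that step is therefore the expectation here, bringing compound 4 close to compound 2 rather than to compound 1; the larger 17-fold higher number from compound 1 to compound 3 (1.22 log units; beyond the scatter) belongs to a group with a hydrogen-bond donor that compound 4 lacks.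

The expected step for compound 4 is a 3.1-fold lower number from compound 3 to compound 4 (0.49 log units; beyond the scatter), a modest fall in the number. Compound 4 is estimated at 22 nM in this assay, with a range of 8 nM to 60 nM.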

Compound 4, inhibition constant: 26 nM
Estimate against measurement, compound 4: 1.2-fold (0.07 log units) below; the measured number falls inside the stated range.
By their numbers in this assay, from the lowest: compound 1; then compounds 2 and 4 (each within the scatter of the next); then compound 3.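

In this assay, replacing 2-ethylbutyl with bis(cyclopropylmethyl)amino on the aromatic carbon next to the ring nitrogen gives a 2.6-fold lower number from compound 3 to compound 4 (0.42 log units; beyond the scatter), so a second tertiary amino group, not only the (cyclopropylmethyl)(propyl)amino group of compound 2, is preferred over the carbon-linked chain at this position. Exchanging the propyl arm for a second cyclopropylmethyl arm gives a 1.4-fold higher number from compound 2 to compound 4 (0.13 log units; within the scatter), so the two dialkylamino groups cannot be told apart here, and this position accepts the added ring on that arm without a change that can be read. The (pentan-3-yl)amino group of compound 1 remains ahead of the new group, with a 6.3-fold higher number from compound 1 to compound 4 (0.80 log units; beyond the scatter), which shows that the second tertiary amino group, like the first, does not reach that compound's number.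

A (methyl)(pentan-3-yl)amino or pentan-3-yloxy group at this position would help separate the roles of the amino hydrogen, the linking atom and the size of the group, and the compounds shown cannot assign the gap to any one of these. No measurement available here explains why these groups differ in this assay.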